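The source may report more compounds than this note shows. Statements on the series, on what has been measured and on what is new or still open speak of the compounds shown alone.

Compound 1 `Cc1c(-c2cnn(Cc3ccc(OC(F)(F)F)cc3)c2)[nH]c2ccccc2c1=O` is the reference point here. In an ADME assay on HepG2 cells (Homo sapiens) for cytotoxicity, read by MTT assay, with a stated time of 24 h (on this read-out lower numbers stand for stronger inhibition and higher numbers for weaker inhibition), compound 1 gives 13000 nM. Two close relatives have been measured beside it. Compound 2 `O=c1c(Cl)c(-c2cnn(Cc3ccc(OC(F)(F)F)cc3)c2)[nH]c2ccccc12`, which carries chloro in place of methyl on an aromatic carbon, gives 28400 nM, and compound 3 `CCc1c(-c2cnn(Cc3ccc(OC(F)(F)F)cc3)c2)[nH]c2ccccc2c1=O`, with methyl in place of hydrogen on a saturated chain carbon bound to an aromatic carbon, gives 19300 nM. The number for compound 3 sits within the scatter of that for compound 1, so the two cannot be told apart, whereas the number for compound 2 lies beyond it: the step of a 2.2-fold higher number from compound 1 to compound 2 (0.34 log units; beyond the scatter) is modest, and the step of a 1.5-fold higher number from compound 1 to compound 3 (0.17 log units; within the scatter) is small.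

Compound 4 `COc1ccc2c(=O)c(C)c(-c3cnn(Cc4ccc(OC(F)(F)F)cc4)c3)[nH]c2c1` differs from compound 1 by methoxy in place of hydrogen on an aromatic carbon. Among the compounds with values here, no measured step touches this part of the shared core, so the only guidance is that the changes seen so far, all on other carbons, moved this assay by at most a modest amount. A change of the same order, in no particular direction, is therefore expected, and the step of a 1.1-fold higher number from compound 1 to compound 4 (0.03 log units; within the scatter) is estimated to stay within the scatter. For compound 4 the expected value in this assay is 14000 nM, with a range from 6000 nM to 32000 nM.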

Compound 4, half-maximal inhibitory concentration: 11000 nM
The estimate for compound 4 lay 1.3-fold (0.10 log units) above the measured number; low and high end bracket the measured number.
By their numbers in this assay, from the lowest: compounds 4, 1, 3 and 2 (each within the scatter of the next, the first and the last beyond it).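

In this assay, putting methoxy in place of hydrogen gives a 1.2-fold lower number from compound 1 to compound 4 (0.07 log units; within the scatter), so compound 1 and compound 4 cannot be told apart. Within the data shown here, this is the first reading from this aromatic carbon of the six-membered ring of carbon only, meta to a fused ring and para to a fused ring, as the earlier steps all concerned other carbons of the shared core. It shows that a group of 2 heavy atoms with 1 hydrogen-bond acceptor and no net charge can sit at this carbon without a change in cytotoxicity that this read-out can resolve, although no evidence at hand bears on why that is so.

A single substituent at a single carbon cannot show whether this holds for other kinds of group, such as a basic amine, a carboxylic acid, a fluoro group or a longer chain like butoxy. It also leaves open whether methoxy would give a similar result on the other aromatic carbons of the same ring.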